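The source may report more compounds than this note shows. Statements on the series, on what has been measured and on what is new or still open speak of the compounds shown alone.

In a physicochemical assay for solubility, in phosphate buffer, measured as kinetic solubility, at pH 7.4 (on this read-out lower numbers stand for lower solubility and higher numbers for higher solubility), compound 3 `Cc1cccc(F)c1-c1nc(CN2CCC(C(=O)NCCCN3C[C@H](C)C[C@H](C)C3)CC2)c(C)o1` gives > 72 ug/mL, which is a limit of the assay and not a number. Compound 1 `Cc1oc(-c2ccc(Cl)cc2)nc1CN1CCC(C(=O)NCCCN2C[C@H](C)C[C@H](C)C2)CC1` gives > 72 ug/mL, also a limit. Compound 2 `Cc1oc(-c2c(Br)cccc2Br)nc1CN1CCC(C(=O)NCCCN2C[C@H](C)C[C@H](C)C2)CC1` gives an actual number, 62.4 ug/mL. Compound 4 `COc1cccc(Cl)c1-c1nc(CN2CCC(C(=O)NCCCN3C[C@H](C)C[C@H](C)C3)CC2)c(C)o1` carries 2-chloro-6-methoxyphenyl in place of 2-fluoro-6-methylphenyl on an aromatic carbon. The measured steps swap this same group. With an at least 1.1-fold lower number from compound 1 to compound 2 (0.06 log units; that floor lies within the scatter) and an at least 1.1-fold higher number from compound 2 to compound 3 (0.06 log units; that floor lies within the scatter), and with a step that the two limits leave unreadable from compound 1 to compound 3, no step beyond the scatter is expected in this assay. The data mostly stop at the limit of > 72 ug/mL in this assay, at which 2 of the 3 values shown sit, so a limit is again possible. The expected change is an at least 1.0-fold lower number from compound 3 to compound 4 (0.02 log units; that floor lies within the scatter). The estimate for compound 4 is 68 ug/mL, with an expected range from 40 ug/mL to 100 ug/mL.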

Compound 4, solubility: > 76 ug/mL
Compound 4 gave a limit, no number (the forecaster's own chance of this, stated with the estimate: 50%); at least 1.1-fold (0.04 log units) between middle value and limit.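

In this assay compound 4 gives > 76 ug/mL, which is a limit of the assay and not a number. This shows that on this aromatic carbon 2-chloro-6-methoxyphenyl, the only group shown with a hydrogen-bond acceptor, also ends at a limit. Against the one real number the change is an at least 1.2-fold higher number from compound 2 to compound 4 (0.08 log units; that floor lies within the scatter), and the steps joining compound 4 to compound 1 and compound 3 cannot be read, as each joins two limits.

From the compounds shown here alone, the true values behind these limits stay open. So does the outcome with a carboxylic acid or an amine on the phenyl ring.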